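The source may hold more compounds than are shown below. What is called first, only, known or untested is meant among the compounds shown, and "the series" means these compounds.

Compound 1 `CCOC(=O)c1c(C)[nH]c(=O)c(C#N)c1-c1ccc([N+](=O)[O-])cc1` gives 95% in a functional assay on aorta (Rattus norvegicus) for inhibition; on this read-out higher numbers stand for larger maximal responses and lower numbers for smaller maximal responses.
Compound 2 `CCOC(=O)c1c(C)[nH]c(=O)c(C#N)c1-c1cccs1` gives 99% in this assay.

Both measured compounds share one core and differ only in the aromatic ring attached to it. Compound 2 reaches a nearly full response in this assay, and the number for compound 1 lies within the usual scatter of that for compound 2, so the two cannot be told apart on these data. Within the data shown here, no step between them is computed here.

Compound 3 `CCOC(=O)c1c(C)[nH]c(=O)c(C#N)c1-c1ccncc1` carries the same core with a different ring: pyridin-4-yl in place of thiophen-2-yl on an aromatic carbon. Among the measured compounds shown here, with only two measured compounds, both near the top of the scale, there is no basis for a step beyond the scatter in either direction. The step of a number 6 percentage points lower from compound 2 to compound 3 (within the scatter) is therefore expected to be small. Compound 3 is expected to give 93%, with a range from 78% to 102%.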

Compound 3, largest response reached (reported as efficacy), in percent of the reference or control that the assay uses: 86.4%
Compound 3: the middle estimate sits 6.6 percentage points above what was measured; measured number inside the range.
By their numbers in this assay, from the lowest: compounds 3, 1 and 2 (each within the scatter of the next, the first and the last beyond it).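

In this assay, pyridin-4-yl in place of thiophen-2-yl on this aromatic carbon gives a number 12.6 percentage points lower from compound 2 to compound 3 (beyond the scatter), so the maximal response does depend, modestly, on which ring sits at this position. Among these compounds, the earlier pair could not be told apart, which makes this the first step to lie beyond the usual scatter. Nothing available explains the step, so which difference between the two rings matters remains unknown.

All the compounds shown carry an aromatic ring at this position, so it remains open how the response would change with a saturated ring such as cyclohexyl or with an open chain such as butyl. As far as these compounds go, it is also open whether a carboxylic acid in place of the ethoxycarbonyl group would shift the response.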